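The source may report more compounds than this note shows. Statements on the series, on what has been measured and on what is new or still open speak of the compounds shown alone.

Measured in a functional assay on HCC78 cells (Homo sapiens) for antiproliferative activity, read by MTT assay, with a stated time of 48 h; on this read-out lower numbers stand for stronger inhibition and higher numbers for weaker inhibition:
compound 1 `COc1ccc(CNC(=O)c2cccc(C(C)Oc3ccnc(Nc4cnn(C)c4)c3)c2)cc1OC` gives 76600 nM
compound 2 `Cc1ccc(CNC(=O)c2cccc(C(C)Oc3ccnc(Nc4cnn(C5CCN(C)CC5)c4)c3)c2)cc1` gives 8100 nM
compound 3 `Cc1ccc(CNC(=O)c2cccc(C(C)Oc3ccnc(Nc4cnn(C)c4)c3)c2)cc1` gives 8900 nM

Among these three numbers compound 3 holds the second highest place. Its nearest neighbour is compound 2: the step of a 1.1-fold higher number from compound 2 to compound 3 (0.04 log units; within the scatter) lies within the scatter, so the two cannot be told apart. Its furthest neighbour is compound 1: the step of an 8.6-fold lower number from compound 1 to compound 3 (0.93 log units; beyond the scatter) is beyond the scatter.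

Compound 4 `Cc1ccc(CNC(=O)c2cccc(C(C)Oc3ccnc(NN4CCOCC4)c3)c2)cc1` differs from compound 3 by morpholin-4-yl in place of 1-methyl-1H-pyrazol-4-yl on a nitrogen on an aromatic ring. Neither measured step bears directly on this change. The step from compound 2 to compound 3 only swapped the group on the aromatic nitrogen of the ring that now leaves, and it stayed within the scatter; the step from compound 1 to compound 3 sits at the opposite end of the molecule. Within the data shown here, with no close precedent, the expectation rests on the shared core alone, and exchanging the whole aromatic ring for a saturated one is expected to weaken inhibition in this assay, giving a 3.4-fold higher number from compound 3 to compound 4 (0.53 log units; beyond the scatter). Compound 4 is therefore estimated at 30000 nM, in a range from 8000 nM to 100000 nM.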

Compound 4, half-maximal inhibitory concentration: 68300 nM
The estimate for compound 4 lay 2.3-fold (0.36 log units) below the measured number, within the range that was stated.
By their numbers in this assay, from the lowest: compounds 2 and 3 (each within the scatter of the next); then compounds 4 and 1 (each within the scatter of the next).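

In this assay, the exchange of (1-methyl-1H-pyrazol-4-yl)amino for (morpholin-4-yl)amino gives a 7.7-fold higher number from compound 3 to compound 4 (0.89 log units; beyond the scatter) and so weakens inhibition, even though the two groups that trade places have equal counts of heavy atoms, hydrogen-bond donors and hydrogen-bond acceptors. Compound 2, with 1-(1-methylpiperidin-4-yl)-1H-pyrazol-4-yl at this place, shows the same picture with an 8.4-fold higher number from compound 2 to compound 4 (0.93 log units; beyond the scatter), whereas the earlier swap on the aromatic nitrogen of the pyrazole stayed within the scatter. The data at hand offer no measurement that explains this loss.

From the compounds shown here alone, whether the loss belongs to morpholin-4-yl itself or follows from any departure from the pyrazole stays open. A phenyl ring or a piperazine on this nitrogen would help separate those two readings.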